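Replacing the 4-methylpiperazin-1-yl group of compound 1

The compounds below may be only part of what the source reports. "The series", "measured", "known", "first", "only" and "open" are said of these compounds alone.

Compound 1 `CN1CCN(C(=O)c2cc(-c3ccccc3)sc2NC(N)=O)CC1` gives "not determined" (no result reported)
Compound 2 `CC(=O)Nc1cccc(-c2cc(C(=O)N[C@H]3CCCNC3)c(NC(N)=O)s2)c1` gives 1800 nM

In a functional assay on HT-29 cells (Homo sapiens) (a higher number here means that more compound is needed for the effect, a lower number that less compound is needed), compound 1 has no single number, so the step that follows starts from no measured value. Compound 3 `CNCCNC(=O)c1cc(-c2ccccc2)sc1NC(N)=O` keeps the core of compound 1 and changes one group: (2-(methylamino)ethyl)amino in place of 4-methylpiperazin-1-yl on a carbonyl carbon with (2-(methylamino)ethyl)amino in place of 4-methylpiperazin-1-yl on a carbonyl carbon. Going by the values given here, with no measured step to draw on, no step of known size or direction can be expected in this assay and the only number available as an anchor is that of compound 2 (1800 nM). Compound 3 is estimated at 1500 nM as the expected value, with an expected range from 300 nM to 8000 nM in this measurement.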

Compound 3, half-maximal effective concentration: 580 nM
The estimate for compound 3 lay 2.6-fold (0.41 log units) above the measured number; the range from low to high includes it.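

In this assay, going by these compounds alone, compound 3 gives 580 nM, but compound 1 has no single number, so no step between compound 1 and compound 3 can be read. As far as these compounds go, what replacing 4-methylpiperazin-1-yl with (2-(methylamino)ethyl)amino does to the potency therefore stays open, and no other evidence bears on this result.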